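This account rests on a few compounds, and the source may have more. Where it says the series, first, only, none or still open, it means among the compounds named here.

Measured so far:
- compound 1, `Cc1ccccc1Nc1nnc(Nc2nc(-c3ccc(Br)cc3)cs2)s1`: 300 mg/kg
- compound 2, `Cc1ccc(Nc2nnc(Nc3nc(-c4ccc(Br)cc4)cs3)s2)cc1`: 100 mg/kg
- compound 3, `Cc1ccccc1Nc1nnc(Nc2nc(-c3ccc([N+](=O)[O-])cc3)cs2)s1`: 100 mg/kg

All three were tested in a functional assay on the whole organism (strain albino) with Mus musculus as the target, in the maximal electroshock model, with a stated time of 4 h; on this read-out lower numbers stand for an effect already at smaller amounts and higher numbers for an effect only at larger amounts of compound. Compound 1 gives 300 mg/kg in this assay, the highest of the three numbers. Compound 2 differs from compound 1 by 4-methylphenyl in place of 2-methylphenyl on a nitrogen on an aromatic ring, and this change gives a 3.0-fold lower number from compound 1 to compound 2 (0.48 log units; beyond the scatter). Compound 3 differs from compound 1 in another part of the molecule, namely (nitro in place of bromo on an aromatic carbon), and this gives a 3.0-fold lower number from compound 1 to compound 3 (0.48 log units; beyond the scatter). Compound 2 and compound 3 stand level at the digits recorded, so nothing separates them in this assay.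

Compound 4, `Cc1ccc(Nc2nnc(Nc3nc(-c4ccc([N+](=O)[O-])cc4)cs3)s2)cc1`, is not yet measured. It differs from compound 3 by 4-methylphenyl in place of 2-methylphenyl on a nitrogen on an aromatic ring. Among the compounds with values here, this is the same change as the one from compound 1 to compound 2: the group that leaves, the group that enters and the place on the shared core are described in the same words for both pairs. What differs between the two pairs is the core itself, and how the core of compound 3 differs from that of compound 1 is given by nitro in place of bromo on an aromatic carbon.

For compound 4 an improvement is expected, of the order of a 2.0-fold lower number from compound 3 to compound 4 (0.30 log units; within the scatter), resting on the step of a 3.0-fold lower number from compound 1 to compound 2 (0.48 log units; beyond the scatter) made by the same change on the other core. Since compound 3 already gives 100 mg/kg, compound 4 is estimated at 50 mg/kg, with a likely range from 30 mg/kg to 100 mg/kg.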

Compound 4, minimum effective dose: 100 mg/kg
For compound 4 the middle estimate is 2.0-fold (0.30 log units) below the measured one, and the stated range covers the measured number.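

In this assay, 4-methylphenyl in place of 2-methylphenyl on the core of compound 3 gives no change at the digits printed from compound 3 to compound 4 (within the scatter), so the gain this change brought on the core of compound 1 did not carry over to this core: the same change on two cores in this assay, a 3.0-fold lower number (0.48 log units; beyond the scatter) from compound 1 to compound 2 and no change at the digits printed (within the scatter) from compound 3 to compound 4, 3.0-fold (0.48 log units) apart, beyond the scatter of two such steps

Read the other way round, nitro in place of bromo gives no change at the digits printed from compound 2 to compound 4 (within the scatter), and this step also differs from the one made by the same change on the other core: the same change on two cores in this assay, a 3.0-fold lower number (0.48 log units; beyond the scatter) from compound 1 to compound 3 and no change at the digits printed (within the scatter) from compound 2 to compound 4, 3.0-fold (0.48 log units) apart, beyond the scatter of two such steps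

The two changes therefore do not simply add up in these four compounds, since each one alone lowers the number from compound 1 while both together go no lower than either alone, but this does not show why, and a single pair of cores cannot say how the change would behave on any further core.

The compounds shown leave open whether an ethyl group in place of the methyl, or a chloro, methoxy or amino group in place of the nitro, would follow compound 2 and compound 3 or break from them. On these data alone, it also remains open whether the same lack of addition would appear in a different kind of test.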